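Swapping a methyl-oxadiazole for a thiophene on a shared core

The compounds below may be only part of what the source reports. "The series", "measured", "known", "first", "only" and "open" are said of these compounds alone.

Four compounds share one core, and they differ only in the five-membered ring attached to the benzene on the nitrogen. Among the compounds with values here, compound 1 `CC(C)(C)C(=O)C1=C(O)C(=O)N(c2ccc(-c3ccon3)cc2)C1c1ccccc1OCCO` is the only one with a number: in an ADME assay on the whole organism (serum, Rattus norvegicus) for protein binding (a lower number here means a smaller unbound share, a higher number a larger unbound share of the compound), compound 1 gives 0.012. Compound 2 `Cc1nc(-c2ccc(N3C(=O)C(O)=C(C(=O)C(C)(C)C)C3c3ccccc3OCCO)cc2)no1` has no result in this assay; compound 2 stands at "not determined" (no result reported). Compound 3 `Cc1noc(-c2ccc(N3C(=O)C(O)=C(C(=O)C(C)(C)C)C3c3ccccc3OCCO)cc2)n1` also has no result; compound 3 stands at "not determined" (no result reported). So where compound 3 stands on this read-out is simply unknown, and no step from a measured neighbour is available to lean on.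

Compound 4 `CC(C)(C)C(=O)C1=C(O)C(=O)N(c2ccc(-c3ccsc3)cc2)C1c1ccccc1OCCO` is the unmeasured one. Its change from compound 3 is thiophen-3-yl in place of 3-methyl-1,2,4-oxadiazol-5-yl on an aromatic carbon. Within the data shown here, no step between measured compounds exists for a change of this kind, so the size and direction of the step from compound 3 to compound 4 in this assay cannot be read from the data; the only anchor is that the closest measured relative, compound 1, sits at a small unbound share. Compound 4 is therefore expected to show a similarly small unbound fraction, estimated at 0.008, with a range from 0.003 to 0.02, because compound 1 gives 0.012.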

Compound 4, unbound fraction: 0.002
Estimate against measurement, compound 4: 4.0-fold (0.60 log units) above; the whole stated range lies above it.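

With compound 4 measured, there are now two values to compare, and they show that the five-membered ring on this aromatic carbon, para to a large group, matters in this assay: placing thiophen-3-yl where 1,2-oxazol-3-yl stood gives a 6.0-fold lower number from compound 1 to compound 4 (0.78 log units; beyond the scatter). Within the data shown here, a single value could not show this, since it gave no sense of how far the unbound share moves when only this ring is exchanged; here the share, already small, becomes smaller still by more than the usual scatter between repeated measurements. Nothing in the material shown accounts for the size or direction of this step.

Steps to or from compound 2 and compound 3 cannot be read: neither has a number, so the two methyl-substituted oxadiazole rings remain unplaced relative to the 1,2-oxazol-3-yl and thiophen-3-yl rings. Also open, from the compounds shown here alone, is how the unbound share would respond at this same place to a group of a different kind, such as a carboxylic acid or an amine, rather than another five-membered aromatic ring.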